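The source may hold more compounds than are shown below. What is called first, only, known or untested is meant among the compounds shown, and "the series" means these compounds.

Working notes, series with the shared core shown in compound 3 `C#CCCn1c(Cc2cc(OC)c(OC)c(OC)c2)nc2c(N)nc(F)nc21` and a varied chain on the aromatic nitrogen. In a functional assay on MCF7 cells (Homo sapiens) for antiproliferative activity (a higher number here means a weaker inhibitor, a lower number a stronger inhibitor), compound 3 gives 25100 nM, the lowest of the three numbers, though each neighbour sits within the scatter of it: compound 1 `C=CCCCn1c(Cc2cc(OC)c(OC)c(OC)c2)nc2c(N)nc(F)nc21` gives 44700 nM and compound 2 `CC[C@H](C)Cn1c(Cc2cc(OC)c(OC)c(OC)c2)nc2c(N)nc(F)nc21` gives 43700 nM. The steps of a 1.8-fold lower number from compound 1 to compound 3 (0.25 log units; within the scatter) and a 1.7-fold lower number from compound 2 to compound 3 (0.24 log units; within the scatter) stay within the scatter, as does a 1.0-fold lower number from compound 1 to compound 2 (0.01 log units; within the scatter). Compound 4 `CCCn1c(Cc2cc(OC)c(OC)c(OC)c2)nc2c(N)nc(F)nc21` differs from compound 3 by methyl in place of ethynyl on a saturated chain carbon, two bonds along the chain from an aromatic nitrogen. Within the data shown here, no measured step removes a triple bond from this chain; the three chain variants so far land close together, so no step beyond the scatter is expected in this assay. The estimate for compound 4 is 35000 nM, range 15000 nM to 80000 nM. The expected step is a 1.4-fold higher number from compound 3 to compound 4 (0.14 log units; within the scatter).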

Compound 4, half-maximal inhibitory concentration: 25100 nM
Beside the measured number, compound 4's estimate is 1.4-fold (0.14 log units) above it, within the range that was stated.
By their numbers in this assay, from the lowest: compounds 3, 4, 2 and 1 (each within the scatter of the next).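

Taking the triple bond out of this chain leaves the result unchanged (this assay), with (no change at the digits printed from compound 3 to compound 4 (within the scatter)), so the propyl chain of compound 4 shows that the triple bond of compound 3 is not required at this position for this read-out. The saturated, unbranched chain also stays level with the other two chains (a 1.7-fold lower number from compound 2 to compound 4 (0.24 log units; within the scatter); a 1.8-fold lower number from compound 1 to compound 4 (0.25 log units; within the scatter)). No measurement on hand explains this flat response.

All four compounds sit within the scatter of one another, so no chain here sets a direction. On these data alone, whether a chain ending in an amine or a carboxylic acid, or a much longer chain, would give a step beyond the scatter remains open.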